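Pyrazolyl for methoxyphenyl on the sulfonamide aryl group

This account rests on a few compounds, and the source may have more. Where it says the series, first, only, none or still open, it means among the compounds named here.

Going by the values given here, compound 2 `COc1cccc(-c2ccc(S(=O)(=O)Nc3cc(N4C[C@@H](C)N[C@@H](C)C4)ccc3OC)cc2)c1` stands lowest of the two numbers so far: in a functional assay for agonist activity at growth hormone secretagogue receptor type 1 (Homo sapiens), read by FLIPR (a higher number here means that more compound is needed for the effect, a lower number that less compound is needed), compound 2 gives 2 nM, while compound 1 `CC(=O)c1ccc(N2C[C@@H](C)N[C@@H](C)C2)cc1NS(=O)(=O)c1ccc(-c2ccccn2)s1` gives 39.8 nM, a gap beyond the scatter. Compound 3 `COc1ccc(N2C[C@@H](C)N[C@@H](C)C2)cc1NS(=O)(=O)c1ccc(-n2cccn2)cc1` is unmeasured; the change is 1H-pyrazol-1-yl in place of 3-methoxyphenyl on an aromatic carbon. Among the compounds with values here, no step between measured compounds covers this exchange. A smaller ring entering for a larger one is expected to weaken the response, so a step of a 5.0-fold higher number from compound 2 to compound 3 (0.70 log units; beyond the scatter) is expected, beyond the scatter. Compound 3 is therefore estimated at 10 nM, with a range from 3 nM to 40 nM.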

Compound 3, half-maximal effective concentration: 15.9 nM
For compound 3 the middle estimate is 1.6-fold (0.20 log units) below the measured one; the measured number falls inside the stated range.
By their numbers in this assay, from the lowest: compound 2; then compound 3; then compound 1.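

Replacing 3-methoxyphenyl with 1H-pyrazol-1-yl on this aromatic carbon, para to a large group, gives the first step read at this position: in this assay it produces an 8.0-fold higher number from compound 2 to compound 3 (0.90 log units; beyond the scatter). The group here therefore bears on the number, yet the exchange does not abolish the agonist response. Nothing available bears on the origin of this step. Still open, as far as these compounds go, is whether the step follows the ring exchange or the loss of the methoxy group. An unsubstituted phenyl, or a phenyl carrying an amine or a carboxylic acid, would help separate the two.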